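The source may report more compounds than this note shows. Statements on the series, on what has been measured and on what is new or still open speak of the compounds shown alone.

Measured compounds:
compound 1, `O/N=C(/Nc1ccc(F)c(Cl)c1)c1ccc2occc2c1`, 5200 nM
compound 2, `O/N=C(/Nc1ccc(F)c(Br)c1)c1ccc2occc2c1`, 1600 nM
compound 3, `COCc1cc2cc(/C(=N\O)Nc3cccc(Cl)c3)ccc2o1`, 1000 nM

All three were tested in an assay on isolated protein for inhibition of Indoleamine 2,3-dioxygenase 1 (Homo sapiens), read by spectrophotometry; on this read-out lower numbers stand for stronger inhibition and higher numbers for weaker inhibition. Compound 1 gives 5200 nM, compound 2 gives 1600 nM, and compound 3 gives 1000 nM.

Compounds 1 and 2 share one core and differ in a single place: bromo in place of chloro on an aromatic carbon. That change brought a 3.3-fold lower number from compound 1 to compound 2 (0.51 log units; beyond the scatter).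

Compound 3 is built on a different core from compound 1; the difference between the two cores is not broken down here. Compound 3 has the lowest number of the three, but its gap to compound 2 lies within the scatter, so these two cannot be ranked against each other, while its gap to compound 1 lies beyond the scatter.

Compound 4, `COCc1cc2cc(/C(=N\O)Nc3cccc(Br)c3)ccc2o1`, has not yet been measured in this assay. It differs from compound 3 in one place: bromo in place of chloro on an aromatic carbon. This is the same kind of change as that between compounds 1 and 2, not the same: in compound 1 the place is ortho to a fluoro group (1 heavy atom), whereas in compound 3 no such group is named around it. Because the measured 3.3-fold lower number from compound 1 to compound 2 (0.51 log units; beyond the scatter) was modest, and the surroundings of the place are not identical, a somewhat smaller step is expected here, a 2.0-fold lower number from compound 3 to compound 4 (0.30 log units; within the scatter). Compound 4 is therefore estimated at 500 nM, expected to fall between 220 nM and 1100 nM.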

Compound 4, half-maximal inhibitory concentration: 930 nM
Compound 4: the middle estimate sits 1.9-fold (0.27 log units) below what was measured; low and high end bracket the measured number.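

In this assay, putting bromo in place of chloro on the 3-chlorophenyl group gave a 1.1-fold lower number from compound 3 to compound 4 (0.03 log units; within the scatter), so on this core the two halogens cannot be told apart. The swap therefore does not carry over at the same size from one core to the other, and the gap between the two steps is larger than chance scatter would readily explain: the same change on two cores in this assay, a 3.3-fold lower number (0.51 log units; beyond the scatter) from compound 1 to compound 2 and a 1.1-fold lower number (0.03 log units; within the scatter) from compound 3 to compound 4, 3.0-fold (0.48 log units) apart, beyond the scatter of two such steps This does not show what sets the size of the step, as the two pairs differ both in the core and in the fluoro group carried by compound 1 and compound 2 but absent from compound 3 and compound 4, and two pairs give no rule for any further core.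

The compounds shown leave open whether adding a fluoro group to the same ring of compound 3 and compound 4 would bring back a step of the earlier size, which would separate the effect of that group from the effect of the core. They also leave open how iodo, methyl or a nitrile would compare with chloro and bromo at this place, and whether an amine or a carboxylic acid in place of the methoxymethyl group would change the picture.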